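Lengthening the Linker: From Compound 3 to Compound 4

A few compounds are considered here, and "the series" means these few. Any claim that something is new, unique, unknown or untested is made for them only; others in the source may bear on it.

Three compounds have been measured so far:
Compound 1 `CC(C)NC(=N)c1ccc2oc(-c3cccc(OCCCOc4ccccc4)c3)cc2c1` in an ADME assay on L6 cells (Rattus norvegicus) for cytotoxicity, read by resazurin assay, with a stated time of 70 h (on this read-out higher numbers stand for weaker inhibition and lower numbers for stronger inhibition), gives 26500 nM.
Compound 2 `CC(C)NC(=N)c1ccc2oc(-c3cccc(OCCCCOc4ccccc4)c3)cc2c1` in this assay gives 36500 nM.
Compound 3 `CC(C)NC(=N)c1ccc2oc(-c3cccc(OCCCCCOc4ccccc4)c3)cc2c1` in this assay gives 10100 nM.

Compound 3 stands at the lowest number of the three, so on this read-out it shows the strongest inhibition of cell growth; its step to each of the other two lies beyond the scatter. The next compound, compound 4 `CC(C)NC(=N)c1ccc2oc(-c3cccc(OCCCCCCOc4ccccc4)c3)cc2c1`, differs from compound 3 in one place: phenoxymethyl in place of phenoxy on a saturated chain carbon, five bonds along the chain from an oxygen on an aromatic ring. Among the measured compounds shown here, this is the same kind of change that links the earlier compounds, each adding one carbon to the chain between the two oxygens. Those steps were uneven. From compound 1 to compound 2 the number moved a 1.4-fold higher number from compound 1 to compound 2 (0.14 log units; within the scatter), whereas a 2.6-fold lower number from compound 1 to compound 3 (0.42 log units; beyond the scatter) and a 3.6-fold lower number from compound 2 to compound 3 (0.56 log units; beyond the scatter) both brought the number down. So the chain extension lowered the number in two of three comparisons, with compound 2 going against a simple pattern. On that basis the step into compound 4 is expected to be small, either within the scatter or a modest lowering, estimated as a 1.4-fold lower number from compound 3 to compound 4 (0.16 log units; within the scatter). Compound 4 is therefore expected to give about 7000 nM, within a range from 3000 nM to 20000 nM.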

Compound 4, half-maximal inhibitory concentration: 7400 nM
Estimate against measurement, compound 4: 1.1-fold (0.02 log units) below; the range from low to high includes it.
By their numbers in this assay, from the lowest: compounds 4 and 3 (each within the scatter of the next); then compounds 1 and 2 (each within the scatter of the next).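

In this assay, phenoxymethyl in place of phenoxy, five bonds along the chain from an oxygen on an aromatic ring, gives a 1.4-fold lower number from compound 3 to compound 4 (0.14 log units; within the scatter), so adding this one carbon brings no readable change here, and the one-carbon change now has a second small step to set beside the first: the same change on two cores in this assay, a 1.4-fold higher number (0.14 log units; within the scatter) from compound 1 to compound 2 and a 1.4-fold lower number (0.14 log units; within the scatter) from compound 3 to compound 4, 1.9-fold (0.27 log units) apart, within the scatter of two such steps.

Larger extensions do read, with a 4.9-fold lower number from compound 2 to compound 4 (0.69 log units; beyond the scatter) and a 3.6-fold lower number from compound 1 to compound 4 (0.55 log units; beyond the scatter), which places compounds 3 and 4 together, apart from compounds 1 and 2, and the one single-carbon step that goes against the small ones is a 3.6-fold lower number from compound 2 to compound 3 (0.56 log units; beyond the scatter). The two-carbon extension also behaves alike on the two cores, so the lower numbers belong to the longer chains as a pair rather than to a steady fall with each added carbon: the same change on two cores in this assay, a 2.6-fold lower number (0.42 log units; beyond the scatter) from compound 1 to compound 3 and a 4.9-fold lower number (0.69 log units; beyond the scatter) from compound 2 to compound 4, 1.9-fold (0.27 log units) apart, within the scatter of two such steps.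

The compounds shown leave open whether a longer chain than that of compound 4 would stay level with compounds 3 and 4 or move away from them. They also leave open how the number would respond if an amine or a carboxylic acid took the place of the phenoxy group at the end of the chain.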